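The source may report more compounds than this note shows. Statements on the series, on what has been measured and on what is new or still open speak of the compounds shown alone.

Measured compounds in the series:
- compound 1 `c1cc(N2CCCC2)nc(Nc2ccc(Oc3ncnc4ccsc34)cc2)n1`, in a functional assay on MDA-MB-231 cells (Homo sapiens) for inhibition, read by MTT assay, with a stated time of 72 h, tested at 20 uM (a lower number here means less inhibition, a higher number more inhibition at the concentration tested (going by the name of the read-out)), compound 1 gives 14.3%
- compound 2 `c1ccc2c(c1)CCN(c1ccnc(Nc3ccc(Oc4ncnc5ccsc45)cc3)n1)C2`, in this assay compound 2 gives 15.4%
- compound 3 `c1cc(N2CCCC2)nc(Nc2ccc(Oc3ncnc4sccc34)cc2)n1`, in this assay compound 3 gives 24.7%

Compound 1 is the lowest of the three numbers, within the scatter of compound 2 and a modest step below compound 3. The step of a number 1.1 percentage points higher from compound 1 to compound 2 (within the scatter) is within the scatter; the step of a number 10.4 percentage points higher from compound 1 to compound 3 (beyond the scatter) is beyond it. Neither step touches the nitrogen on the aromatic ring that is changed in compound 4.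

Compound 4 `CN(c1ccc(Oc2ncnc3ccsc23)cc1)c1nccc(N2CCCC2)n1` differs from compound 1 by methyl in place of hydrogen on a nitrogen on an aromatic ring. Going by the values given here, no measured pair in the set changes this position, so the two measured steps give no direct guide to the size or direction of the change. The two measured steps are of small to modest size, and the expectation for a change of one heavy atom at the shared core is therefore a step that stays near or within the scatter, with no firm direction. The estimated step from compound 1 to compound 4 is a number 2.3 percentage points lower from compound 1 to compound 4 (within the scatter).

In this assay compound 4 is expected to give about 12%, with a range from 2% to 25%.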

Compound 4, a percentage reported as inhibition, at one concentration (the size of the read-out at that concentration, not a potency): 38%
Compound 4: middle estimate off by 26 percentage points, on the low side, outside the stated range (above it).
By their numbers in this assay, from the lowest: compounds 1, 2 and 3 (each within the scatter of the next, the first and the last beyond it); then compound 4.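

In this assay, methyl in place of hydrogen on the nitrogen on an aromatic ring gives a number 23.7 percentage points higher from compound 1 to compound 4 (beyond the scatter), which shows that this nitrogen is a place in the series where the addition of one heavy atom can move the read-out upward. This step is larger than both changes seen earlier, at other places in the molecule: a number 1.1 percentage points higher from compound 1 to compound 2 (within the scatter) and a number 10.4 percentage points higher from compound 1 to compound 3 (beyond the scatter), so this nitrogen is the most responsive of the three places changed so far, on the evidence of a single pair. No measurement at hand bears on why the number rises with this change.

The compounds shown leave open whether ethyl, a longer chain or an acetyl group on this nitrogen would raise the number further, or whether the step depends on methyl itself. Also open, as far as these compounds go, is whether methyl on this nitrogen gives a step of similar size alongside the 1,2,3,4-tetrahydroisoquinolin-2-yl group of compound 2 or on the core of compound 3.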